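Benzoyl for phenylsulfonyl on the chain carbon of compound 3

This account rests on a few compounds, and the source may have more. Where it says the series, first, only, none or still open, it means among the compounds named here.

Compound 3 `N#C/C(=C\c1c(-c2ccccc2)[nH]c2ccccc12)S(=O)(=O)c1ccccc1` gives 2600 nM in a functional assay on UACC-62 cells (Homo sapiens) for inhibition, read by sulforhodamine B assay, with a stated time of 48 h; on this read-out lower numbers stand for stronger inhibition of growth and higher numbers for weaker inhibition of growth. Compound 2 `COc1ccc2[nH]c(-c3ccccc3)c(/C=C(\C#N)S(=O)(=O)c3ccccc3)c2c1` gives 3800 nM, and the step of a 1.5-fold lower number from compound 2 to compound 3 (0.16 log units; within the scatter) is within the scatter, so the two stand level. Compound 1 `COc1ccc(-c2[nH]c3ccccc3c2/C=C(\C#N)S(=O)(=O)c2ccccc2)cc1` gives 597 nM, and the step of a 4.4-fold higher number from compound 1 to compound 3 (0.64 log units; beyond the scatter) sets compound 3 clearly apart from it. Compound 4 `N#C/C(=C\c1c(-c2ccccc2)[nH]c2ccccc12)C(=O)c1ccccc1` differs from compound 3 by benzoyl in place of phenylsulfonyl on a double-bonded chain carbon bound to a double-bonded chain carbon and a triple-bonded carbon. Going by the values given here, neither measured step bears on this change: both concern hydrogen in place of methoxy on an aromatic carbon, one modest and one within the scatter, and no measured pair exchanges the group on the chain carbon. The step of no change at the digits printed from compound 3 to compound 4 (within the scatter) is therefore expected without a firm direction and with a wide band. Compound 4 is estimated at 2600 nM, with a range from 700 nM to 10000 nM.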

Compound 4, concentration for 50% growth inhibition: 3600 nM
Beside the measured number, compound 4's estimate is 1.4-fold (0.14 log units) below it, and the stated range covers the measured number.
By their numbers in this assay, from the lowest: compound 1; then compounds 3, 4 and 2 (each within the scatter of the next).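

In this assay the exchange of phenylsulfonyl for benzoyl on the chain carbon leaves the two compounds level (a 1.4-fold higher number from compound 3 to compound 4 (0.14 log units; within the scatter)). On this core, then, this position accepts benzoyl as well as phenylsulfonyl, and the sulfonyl group is not required to hold this level of growth inhibition. Nothing available explains why the two groups read level.

As far as these compounds go, whether benzoyl also stands level with phenylsulfonyl on the methoxy-bearing core of compound 1 remains open. From the compounds shown here alone, the outcome with a methyl ester or an acetyl group on the chain carbon is also open.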